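One More Methyl on a Long Chain

A few compounds are considered here, and "the series" means these few. Any claim that something is new, unique, unknown or untested is made for them only; others in the source may bear on it.

Values in a functional assay on HCT-116 cells (Homo sapiens) for antiproliferative activity, read by MTT assay, with a stated time of 48 h (a lower number here means a stronger inhibitor, a higher number a weaker inhibitor), as measured so far
Compound 1 `CCCCCCC(CCO)n1cnc2c(N)ncnc21` gives > 50000 nM as a limit of the assay and not a number
Compound 2 `CCCCCCCCC(CCO)n1cnc2c(N)ncnc21` gives 11600 nM as its value
Compound 3 `CCCCCCCCCC(CCO)n1cnc2c(N)ncnc21` gives 10500 nM as its value

Compound 3 and compound 2 sit together in this assay with no gap beyond the scatter. Compound 4 `CCCCCCCCCCC(CCO)n1cnc2c(N)ncnc21` carries one change from compound 3, methyl in place of hydrogen on a saturated chain carbon, ten or more bonds along the chain from an aromatic nitrogen and nothing else. The closest guide is a matching swap of methyl in place of hydrogen on this chain, a 1.1-fold lower number from compound 2 to compound 3 (0.04 log units; within the scatter) and thus no real shift. Larger drops appear in an at least 4.3-fold lower number from compound 1 to compound 2 (0.63 log units; beyond the scatter) and in an at least 4.7-fold lower number from compound 1 to compound 3 (0.67 log units; beyond the scatter) but those swaps add ethyl and propyl. Both rest on the limit of > 50000 nM in this assay, at which 1 of the 3 values shown sits, and not on a number. With the matching swap as the best guide, no step beyond the scatter is expected in this assay here. The expected step is a 1.1-fold lower number from compound 3 to compound 4 (0.04 log units; within the scatter) and it stays small. For compound 4 the estimated value is 9500 nM with an expected range from 4500 nM to 25000 nM in this estimate.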

Compound 4, half-maximal inhibitory concentration: 2590 nM
For compound 4 the middle estimate is 3.7-fold (0.56 log units) above the measured one; the whole stated range lies above it.
By their numbers in this assay, from the lowest: compound 4; then compounds 3 and 2 (each within the scatter of the next). At a limit, above all of these: compound 1.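

Methyl in place of hydrogen stayed within the scatter at nine bonds along the chain, a 1.1-fold lower number from compound 2 to compound 3 (0.04 log units; within the scatter), but on the longer chain the same change gives a 4.1-fold lower number from compound 3 to compound 4 (0.61 log units; beyond the scatter). So in this assay the number does not fall evenly as the chain grows, and ethyl in place of hydrogen at nine bonds along the chain gives a 4.5-fold lower number from compound 2 to compound 4 (0.65 log units; beyond the scatter). Across the whole series the drop is an at least 19-fold lower number from compound 1 to compound 4 (1.28 log units; beyond the scatter), but compound 1 stands at a limit and not a number: the limit of > 50000 nM in this assay, at which 1 of the 4 values shown sits.

The compounds shown leave open whether a longer chain would lower the number further or raise it again. Also open, from the compounds shown here alone, is what an amine or a carboxylic acid in place of the hydroxyl would do to this value.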